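Replacing 2,6-dibromophenyl with 2-chloro-6-methoxyphenyl: a half-life estimate

This account rests on a few compounds, and the source may have more. Where it says the series, first, only, none or still open, it means among the compounds named here.

In an ADME assay on microsomes from liver (Rattus norvegicus) for metabolic stability, read by LC-MS, using NADPH, at 37 degrees C (on this read-out lower numbers stand for a shorter-lived compound and higher numbers for a longer-lived compound), compound 1 `Cc1oc(-c2c(Cl)cccc2Cl)nc1CN1CCC(C(=O)NCCCN2C[C@H](C)C[C@H](C)C2)CC1` gives 0.0483 h and compound 2 `Cc1oc(-c2c(Br)cccc2Br)nc1CN1CCC(C(=O)NCCCN2C[C@H](C)C[C@H](C)C2)CC1` gives 0.035 h. Going by the values given here, these are the only two measurements so far, and they lie within the scatter of each other, so compound 2 cannot be ranked against compound 1. Compound 3 `COc1cccc(Cl)c1-c1nc(CN2CCC(C(=O)NCCCN3C[C@H](C)C[C@H](C)C3)CC2)c(C)o1` keeps the shared core and changes one group: 2-chloro-6-methoxyphenyl in place of 2,6-dibromophenyl on an aromatic carbon. That is 2-chloro-6-methoxyphenyl in place of 2,6-dibromophenyl on an aromatic carbon. Among the compounds with values here, the only measured step that bears on this change is a 1.4-fold lower number from compound 1 to compound 2 (0.14 log units; within the scatter), which stays within the scatter. That step exchanged 2,6-dichlorophenyl for 2,6-dibromophenyl, whereas compound 3 brings in a methoxy group that neither measured compound carries, so the guidance is thin. No step beyond the scatter is therefore expected in this assay. The estimated change is a 1.1-fold higher number from compound 2 to compound 3 (0.06 log units; within the scatter), and a real move in either direction remains possible. For compound 3 the expected half-life is 0.04 h, with an estimated range from 0.02 h to 0.08 h.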

Compound 3, half-life: 0.055 h
Compound 3: middle estimate off by 1.4-fold (0.14 log units), on the low side; low and high end bracket the measured number.
By their numbers in this assay, from the lowest: compounds 2, 1 and 3 (each within the scatter of the next).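

In this assay, going by these compounds alone, the swap to 2-chloro-6-methoxyphenyl, a 1.6-fold higher number from compound 2 to compound 3 (0.20 log units; within the scatter), stays inside the usual scatter, and so does the single exchange of methoxy for chloro, a 1.1-fold higher number from compound 1 to compound 3 (0.06 log units; within the scatter). This aromatic group has now carried chlorine, bromine and a mix of chlorine and methoxy, including the hydrogen-bond acceptor that methoxy adds, and the three half-lives cannot be told apart. Nothing here explains why these exchanges leave the number within the scatter.

On these data alone, whether an amine, a carboxylic acid or a longer chain such as ethoxy on this phenyl ring would move the half-life beyond the scatter stays open. The three compounds also differ only in this one group, so they cannot show whether a change elsewhere in the shared core would shift the number, which for compound 3 is 0.055 h.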